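From naphthalen-2-yl to 1-benzofuran-2-yl on one ring carbon

The source may hold more compounds than are shown below. What is called first, only, known or untested is meant among the compounds shown, and "the series" means these compounds.

Compound 1 `C[C@@]1(O)[C@H](O)[C@@H](CO)O[C@H]1n1cc(I)c2c(N)ncnc21`: 7500 nM
Compound 2 `C[C@@]1(O)[C@H](O)[C@@H](CO)O[C@H]1n1cc(-c2ccc3ccccc3c2)c2c(N)ncnc21`: > 10000 nM

In a functional assay on HeLa S3 cells (Homo sapiens) for cytotoxicity, read by XTT assay, with a stated time of 3 days (a higher number here means a weaker inhibitor, a lower number a stronger inhibitor), compound 2 gives > 10000 nM, which is a limit of the assay and not a number. Compound 3 `C[C@@]1(O)[C@H](O)[C@@H](CO)O[C@H]1n1cc(-c2cc3ccccc3o2)c2c(N)ncnc21` carries 1-benzofuran-2-yl in place of naphthalen-2-yl on the same aromatic carbon: 1-benzofuran-2-yl in place of naphthalen-2-yl on an aromatic carbon. For the measured compounds named here, the only measured step at this carbon is an at least 1.3-fold higher number from compound 1 to compound 2 (0.12 log units; that floor lies within the scatter), and it gives no sign of a change beyond the scatter. No step beyond the scatter is therefore expected, and the estimated step is a step that the limit leaves unreadable from compound 2 to compound 3. For compound 3 the expected value is 11000 nM, with an estimated range of 5000 nM to 25000 nM.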

Compound 3, half-maximal inhibitory concentration: > 10000 nM
Compound 3: only a limit was reported; the forecaster's own chance of this, stated with the estimate: 60%; the middle value lies beyond the limit too.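

In this assay, compound 3 gives only a limit of the assay, as compound 2 does, so exchanging naphthalen-2-yl for 1-benzofuran-2-yl, with its ring oxygen, yields no readable value at this carbon. Set against iodo, the change is an at least 1.3-fold higher number from compound 1 to compound 3 (0.12 log units; that floor lies within the scatter). The step between compound 2 and compound 3 cannot be read: the limit of > 10000 nM in this assay, at which 2 of the 3 values shown sit.

From the compounds shown here alone, whether compound 2 or compound 3 truly differs from compound 1 beyond the scatter stays open. So does whether an amine or a carboxylic acid on this carbon would give a readable value.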